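This account rests on a few compounds, and the source may have more. Where it says the series, first, only, none or still open, it means among the compounds named here.

Values in an ADME assay on HEK293 cells (Homo sapiens) for cytotoxicity, with a stated time of 6 h; on this read-out higher numbers stand for lower toxicity in this test and lower numbers for higher toxicity in this test:
Compound 1 `CCCCNc1nc(N)nc2cccc(Cl)c12`: 100 nM
Compound 2 `CCCCNc1nc(N)nc2cccc(CC3CCCC3)c12`: > 25000 nM, a limit of the assay
Compound 3 `CCCCNc1nc(N)nc2cccc(OCc3ccccc3)c12`: 10000 nM

Compound 3 has the higher of the two values that are numbers and not limits. Compound 4 `CCCCNc1nc(N)nc2cccc(OCc3cccnc3)c12` differs from it as follows: pyridin-3-yl in place of phenyl on a saturated chain carbon bound to an oxygen on an aromatic ring. Among the compounds with values here, no measured step makes this exact change. The closest steps exchange the whole group on the shared core. One is large: a 100-fold higher number from compound 1 to compound 3 (2.00 log units; beyond the scatter). The other is at least modest: an at least 2.5-fold lower number from compound 2 to compound 3 (0.39 log units; beyond the scatter). The change to compound 3, at 10000 nM, is narrower, as it stays within the benzyloxy frame, so no shift beyond the scatter is expected. The expected step is a 1.2-fold higher number from compound 3 to compound 4 (0.08 log units; within the scatter). For compound 4 the estimated value is 12000 nM, expected between 5000 nM and 25000 nM.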

Compound 4, half-maximal cytotoxic concentration: > 25000 nM
Compound 4 was reported as a limit; the forecaster's own chance of this, stated with the estimate: 25%; at least 2.0-fold (0.31 log units) between middle value and limit.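

The earlier compounds shown here exchanged the whole group on the shared core, whereas compound 4 shows that a narrower change within the benzyloxy frame, pyridin-3-yl in place of phenyl, also moves the read-out in this assay, giving an at least 2.5-fold higher number from compound 3 to compound 4 (0.39 log units; beyond the scatter). Set against the chloro group, (pyridin-3-yl)methoxy gives an at least 250-fold higher number from compound 1 to compound 4 (2.39 log units; beyond the scatter). Compound 4 is reported as a limit and not a number, and its step with compound 2, also a limit, cannot be read: the limit of > 25000 nM in this assay, at which 2 of the 4 values shown sit.

From the compounds shown here alone, how far past that limit compound 4 truly lies remains open. Also open, going by these compounds, is whether an amine or a carboxylic acid in place of pyridin-3-yl would give a number this high.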